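Morpholine for piperidine on the thiocarbonyl: two cores compared

A few compounds are considered here, and "the series" means these few. Any claim that something is new, unique, unknown or untested is made for them only; others in the source may bear on it.

Compound 1 `Cc1ccc2c(=O)c(CSC(=S)N3CCCCC3)coc2c1` gives 900 nM in a functional assay on HEp-2 cells (Homo sapiens) for antiproliferative activity, read by MTT assay, with a stated time of 72 h; a lower number here means a stronger inhibitor, a higher number a weaker inhibitor. Compound 2 `Cc1ccc2c(=O)c(CSC(=S)N3CCOCC3)coc2c1` carries morpholin-4-yl in place of piperidin-1-yl on a thiocarbonyl carbon and gives 4000 nM; the step of a 4.4-fold higher number from compound 1 to compound 2 (0.65 log units; beyond the scatter). Compound 3 `CCOC(=O)c1cc(=O)c2cc(CSC(=S)N3CCCCC3)ccc2o1` is built on a different core; the difference between the two cores is not broken down here. In this assay compound 3 gives 3400 nM. Compound 4 `CCOC(=O)c1cc(=O)c2cc(CSC(=S)N3CCOCC3)ccc2o1` is not yet measured and carries the same change, (morpholin-4-yl in place of piperidin-1-yl on a thiocarbonyl carbon). Within the data shown here, the expectation for compound 4 rests on the single earlier instance, from compound 1 to compound 2, and a step of about that size, a 4.1-fold higher number from compound 3 to compound 4 (0.61 log units; beyond the scatter), is estimated, though it was seen only once and on another core. The estimated value for compound 4 is 14000 nM, in a range from 6000 nM to 35000 nM.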

Compound 4, half-maximal inhibitory concentration: > 25000 nM
Compound 4: no number, only a limit; the forecaster's own chance of this, stated with the estimate: 10%; middle value at least 1.7-fold (0.25 log units) from the limit.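

In this assay the change from piperidin-1-yl to morpholin-4-yl again goes towards a higher number on the second core, with an at least 7.3-fold higher number from compound 3 to compound 4 (0.86 log units; beyond the scatter). Compound 4 gives > 25000 nM, which is a limit of the assay and not a number. The direction of the change therefore holds on both cores shown, but the size of the step on the second core stays unknown and no equality or difference between the two steps can be claimed: the same change on two cores in this assay, a 4.4-fold higher number (0.65 log units; beyond the scatter) from compound 1 to compound 2 and an at least 7.3-fold higher number (0.86 log units; beyond the scatter) from compound 3 to compound 4; the limit leaves it open whether they differ

From the compounds shown here alone, only piperidin-1-yl and morpholin-4-yl appear on the thiocarbonyl carbon, so it remains open how piperazin-1-yl or an open-chain diethylamino group would compare on either core. Also open, going by these compounds, is how a free carboxylic acid in place of the ethyl ester of compound 3 would read.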